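A Smaller Hydroxyalkyl Chain on the Amine Nitrogen

The source may report more compounds than this note shows. Statements on the series, on what has been measured and on what is new or still open speak of the compounds shown alone.

Of the compounds shown here, three on a shared core have been measured in an in vitro assay on 293-EBNA cells for binding affinity to corticotropin-releasing factor receptor 1 (Homo sapiens); on this read-out lower numbers stand for stronger inhibition and higher numbers for weaker inhibition. Compound 1 `CCC(COC)N(C)c1nc(C)nc2c1nnn2-c1ccc(C(C)C)cc1Br` gives 11.2 nM. Compound 2 `CCN(c1nc(C)nc2c1nnn2-c1ccc(C(C)C)cc1Br)C(COC)COC` gives 123 nM. Compound 3 `CCCC(CN(C)C)Nc1nc(C)nc2c1nnn2-c1ccc(C(C)C)cc1Br` gives 38.7 nM, the second highest of the three numbers; the step of an 11-fold higher number from compound 1 to compound 2 (1.04 log units; beyond the scatter) was large, the step of a 3.5-fold higher number from compound 1 to compound 3 (0.54 log units; beyond the scatter) was modest, and the step of a 3.2-fold lower number from compound 2 to compound 3 (0.50 log units; beyond the scatter) was modest in the opposite direction.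

Compound 4 `CCC(CO)Nc1nc(C)nc2c1nnn2-c1ccc(C(C)C)cc1Br` differs from compound 3 in one place: a group of 5 heavy atoms (4 carbon, 1 oxygen; no ring) in place of a group of 8 heavy atoms (7 carbon, 1 nitrogen; no ring), on a nitrogen on an aromatic ring. Within the data shown here, none of the measured steps alters a group on this nitrogen alone; each of them exchanges the whole amino group on the aromatic carbon. Together they show that this part of the molecule shifts the numbers in this assay by modest to large amounts, in both directions, but they do not say what a 1-(hydroxymethyl)propyl group in place of the longer chain will do. The step of a 1.6-fold higher number from compound 3 to compound 4 (0.19 log units; within the scatter) is therefore expected to be modest at most, and its direction remains uncertain. Compound 4 is estimated at 60 nM in this assay, with a range from 15 nM to 250 nM.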

Compound 4, inhibition constant: 25.3 nM
Beside the measured number, compound 4's estimate is 2.4-fold (0.38 log units) above it, within the range that was stated.
By their numbers in this assay, from the lowest: compound 1; then compounds 4 and 3 (each within the scatter of the next); then compound 2.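

In this assay, among these compounds, this is the first step that can be read for a chain on this nitrogen alone: the step, a 1.5-fold lower number from compound 3 to compound 4 (0.18 log units; within the scatter), shows that a 1-(hydroxymethyl)propyl group, smaller than the chain it replaces and carrying a hydrogen-bond donor that chain lacks, gives a number that cannot be told apart from that of the longer chain. The whole amino group on the aromatic carbon still matters, as the new compound keeps a clear margin on both sides: a 4.9-fold lower number from compound 2 to compound 4 (0.69 log units; beyond the scatter), and a 2.3-fold higher number from compound 1 to compound 4 (0.35 log units; beyond the scatter), which leaves compound 1 the strongest of the four. Nothing shown here explains these results.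

On these data alone, it remains open what a carboxylic acid or a longer chain ending in a hydroxyl would do in place of the 1-(hydroxymethyl)propyl group on this nitrogen, and whether a plain butyl chain would give a number in the same range. Also open, as far as these compounds go, is whether a methyl group added to this nitrogen, with the hydroxyl kept, would bring the number closer to that of compound 1.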